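Series notes: sulfonyl aryl variation on a shared core

This account rests on a few compounds, and the source may have more. Where it says the series, first, only, none or still open, it means among the compounds named here.

Measured so far in a functional assay on the whole organism (strain Jcl:Sprague-Dawley) for inhibition, with Rattus norvegicus as the target, with stated times of 3 min and 3 h, at a dose of 1 mg/kg by the intravenous route; on this read-out higher numbers stand for more inhibition at the one dose given (going by the name of the read-out) and lower numbers for less inhibition:
compound 1 `CNCc1cn(S(=O)(=O)c2ccco2)c(-c2cccnc2F)c1F` gives 75%
compound 2 `CNCc1cn(S(=O)(=O)c2cc(OC)ccn2)c(-c2cccnc2F)c1F` gives 95%
compound 3 `CNCc1cn(S(=O)(=O)c2cccc(C)n2)c(-c2cccnc2F)c1F` gives 91%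

Compound 3 stands second highest of the three; its value and that of compound 2 lie within the scatter of each other, while compound 1 lies beyond it. The unmeasured compound 4 `CNCc1cn(S(=O)(=O)c2ccc(F)cn2)c(-c2cccnc2F)c1F` differs from compound 3 as follows: 5-fluoropyridin-2-yl in place of 6-methylpyridin-2-yl on a sulfonyl sulfur. Steps that bear on this are a number 20 percentage points higher from compound 1 to compound 2 (beyond the scatter) and a number 16 percentage points higher from compound 1 to compound 3 (beyond the scatter), both exchanges of the group on the sulfonyl sulfur, and a number 4 percentage points lower from compound 2 to compound 3 (within the scatter), an exchange of the same kind as the one proposed. In this assay no step beyond the scatter is therefore expected. The expected step is a number 1 percentage points lower from compound 3 to compound 4 (within the scatter). Compound 4 is estimated near 90%, within 78% to 98%.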

Compound 4, a percentage reported as inhibition, in the whole organism at one dose (the size of the read-out at that dose, not a potency): 87%
Compound 4: the middle estimate sits 3 percentage points above what was measured, and the stated range covers the measured number.
By their numbers in this assay, from the lowest: compound 1; then compounds 4, 3 and 2 (each within the scatter of the next).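

In this assay, a fluorine-bearing pyridine on the sulfonyl sulfur fits with the methyl- and methoxy-bearing ones: 5-fluoropyridin-2-yl gives a number 4 percentage points lower from compound 3 to compound 4 (within the scatter) and a number 8 percentage points lower from compound 2 to compound 4 (within the scatter). Three differently substituted pyridin-2-yl groups therefore cannot be told apart here. Going by these compounds alone, the change from furan-2-yl also holds for this third pyridine, with a number 12 percentage points higher from compound 1 to compound 4 (beyond the scatter), though compound 1 remains the only compound without a pyridine.

Nothing at hand accounts for these numbers. Open, as far as these compounds go, is whether a pyridin-2-yl carrying an amine or a carboxylic acid on the sulfonyl sulfur keeps this level.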